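This account rests on a few compounds, and the source may have more. Where it says the series, first, only, none or still open, it means among the compounds named here.

Working notes on the sulfonamide series in a functional assay on B16-F10 cells (Mus musculus) for antiproliferative activity, read by MTT assay, with a stated time of 48 h; a lower number here means a stronger inhibitor, a higher number a weaker inhibitor.

Compound 2 `Cc1ncc([N+](=O)[O-])n1CC(=O)NS(=O)(=O)c1ccc(F)cc1` gives 0.35 ug/mL and stands lowest of the three numbers measured. Going by the values given here, compound 1 `Cc1ncc([N+](=O)[O-])n1CC(=O)NS(=O)(=O)c1ccc(Cl)cc1`, the chloro analogue, gives 0.92 ug/mL; the step of a 2.6-fold lower number from compound 1 to compound 2 (0.42 log units; beyond the scatter) is the only single-point change measured and is the one that bears on the next step. Among the compounds with values here, compound 3 `O=C(Cc1ccc(F)cc1)NS(=O)(=O)c1ccc(Cl)cc1` differs from compound 1 in several places at once; in this assay compound 3 gives 6.36 ug/mL, and the two values show only that compound 3 sits far higher, with nothing said here about any single step to it.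

Compound 4 `Cc1ncc([N+](=O)[O-])n1CC(=O)NS(=O)(=O)c1ccccc1` differs from compound 2 by hydrogen in place of fluoro on an aromatic carbon, on an aromatic carbon of a six-membered aromatic ring of carbon only, para to a large group. Going from chloro to fluoro at this place lowered the number modestly; going from fluoro to hydrogen has no measured precedent, so the direction is open. The expected step of a 1.7-fold higher number from compound 2 to compound 4 (0.23 log units; within the scatter) is therefore small, with a mild increase judged somewhat more likely than a further decrease. Compound 4 is estimated at 0.6 ug/mL, within a range of 0.2 ug/mL to 2 ug/mL.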

Compound 4, half-maximal inhibitory concentration: 2.93 ug/mL
Beside the measured number, compound 4's estimate is 4.9-fold (0.69 log units) below it; the measured number lies above the stated range.
By their numbers in this assay, from the lowest: compound 2; then compound 1; then compound 4; then compound 3.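

In this assay, this place, on an aromatic carbon para to a large group, now has a reading without a halogen, and the number rises with either halogen removed: fluoro to hydrogen gives an 8.4-fold higher number from compound 2 to compound 4 (0.92 log units; beyond the scatter), and chloro to hydrogen gives a 3.2-fold higher number from compound 1 to compound 4 (0.50 log units; beyond the scatter). With the earlier halogen comparison, the three compounds order from the lowest number as fluoro, chloro, hydrogen, so the halogens at this place go with lower numbers among compounds 1, 2 and 4, and the 4-fluorophenyl to phenyl change is the largest of the steps there. Nothing available explains this order.

Going by these compounds, whether bromo, methoxy or an amine at this place would fall within this order remains open. On these data alone, whether the same change would act alike on the core of compound 3 also remains open.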